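A few compounds are considered here, and "the series" means these few. Any claim that something is new, unique, unknown or untested is made for them only; others in the source may bear on it.

The compounds share one core, seen in compound 1 `O=C1NC(c2ccccc2)CN1S(=O)(=O)c1ccc2c(c1)CCCN2`, where a hydrogen sits on the ring nitrogen. In a functional assay on K562 cells (Homo sapiens) for antiproliferative activity, read by MTT assay (on this read-out higher numbers stand for weaker inhibition and lower numbers for stronger inhibition), compound 1 gives only a limit of the method, > 20000 nM. Compound 2 `COC(=O)N1CCCc2cc(S(=O)(=O)N3CC(c4ccccc4)NC3=O)ccc21` carries a methoxycarbonyl on that nitrogen. In this assay compound 2 likewise gives only a limit, > 20000 nM. Compound 3 `CCCCOC(=O)N1CCCc2cc(S(=O)(=O)N3CC(c4ccccc4)NC3=O)ccc21` carries a butoxycarbonyl instead, and in this assay compound 3 gives 3680 nM. The step of an at least 5.4-fold lower number from compound 2 to compound 3 (0.73 log units; beyond the scatter) shows that a longer chain on the oxygen brought the number down from the limit, and the step of an at least 5.4-fold lower number from compound 1 to compound 3 (0.73 log units; beyond the scatter) reads the same way starting from the unsubstituted nitrogen. The step that the two limits leave unreadable from compound 1 to compound 2 cannot be sized, since both values sit at the limit of > 20000 nM in this assay, at which 2 of the 3 values shown sit.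

Compound 4 `O=C(NC1CCCCC1)N1CCCc2cc(S(=O)(=O)N3CC(c4ccccc4)NC3=O)ccc21` differs from compound 2 by cyclohexylamino in place of methoxy on a carbonyl carbon. For the measured compounds named here, the only two steps that end in a number both lead to compound 3, both came with a larger group on the carbonyl carbon, and both gave clearly lower numbers. The cyclohexylamino group is larger still, so a lowering of similar size is expected here. Compound 4 is therefore estimated at 3500 nM, between 900 nM and 15000 nM, an expected step of an at least 5.7-fold lower number from compound 2 to compound 4 (0.75 log units; beyond the scatter).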

Compound 4, half-maximal inhibitory concentration: 813 nM
For compound 4 the middle estimate is 4.3-fold (0.63 log units) above the measured one, and the stated range ends above it.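

On the carbonyl carbon, the step of a 4.5-fold lower number from compound 3 to compound 4 (0.66 log units; beyond the scatter) shows that the number can fall further than butoxy took it, and compound 4 has the lowest number of the four compounds in this assay. This change is also the first shown that puts a nitrogen rather than an oxygen on that carbon, bringing a six-membered carbon ring and a hydrogen-bond donor, so a lower number at this position does not depend on an oxygen-linked chain; against the weakest end of the series, the result reads as an at least 24-fold lower number from compound 2 to compound 4 (1.39 log units; beyond the scatter) and as an at least 24-fold lower number from compound 1 to compound 4 (1.39 log units; beyond the scatter). Those two sizes are minimum sizes and not exact ones, since each step starts from a limit of the method: the limit of > 20000 nM in this assay, at which 2 of the 4 values shown sit.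

The compounds shown leave open whether the lower number comes from the nitrogen, the ring or both, since cyclohexylamino brings them together. A butylamino group, which keeps the nitrogen with an open chain, and a cyclohexyloxy group, which keeps the ring on an oxygen, would separate the two on the same carbonyl carbon.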